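The compounds below may be only part of what the source reports. "The series", "measured", "known", "first", "only" and "open" are said of these compounds alone.

In a functional assay on Bel-7402 cells (Homo sapiens) for cytotoxicity, read by MTT assay (on this read-out higher numbers stand for weaker inhibition and lower numbers for stronger inhibition), compound 1 (`CCn1cc(C(=O)Nc2ccccc2N)c(=O)c2cc(F)c(N3CCNC(C)C3)c(F)c21`) gives 4800 nM and compound 3 (`CCn1cc(C(=O)Nc2ccc(OC)cc2)c(=O)c2cc(F)c(N3CCNC(C)C3)c(F)c21`) gives 5400 nM, two values within the scatter of each other. Compound 2 (`CCn1cc(C(=O)Nc2ccc(C)c([N+](=O)[O-])c2)c(=O)c2cc(F)c(N3CCNC(C)C3)c(F)c21`) gives a clearly higher number, 29100 nM. Compound 4 (`CCn1cc(C(=O)Nc2ccc(C(C)=O)cc2)c(=O)c2cc(F)c(N3CCNC(C)C3)c(F)c21`) differs from compound 1 by 4-acetylphenyl in place of 2-aminophenyl on an amide-type nitrogen. Two measured steps change the same group. The step of a 1.1-fold higher number from compound 1 to compound 3 (0.05 log units; within the scatter) stays within the scatter, while the step of a 6.1-fold higher number from compound 1 to compound 2 (0.78 log units; beyond the scatter) is modest. A small rise in the number is therefore expected in this assay, lying between those two steps and possibly no larger than the scatter. The expected step is a 2.0-fold higher number from compound 1 to compound 4 (0.30 log units; within the scatter). The estimate for compound 4 is 9500 nM, with an expected range from 3800 nM to 26000 nM.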

Compound 4, half-maximal inhibitory concentration: > 50000 nM
Compound 4: only a limit was reported; the forecaster's own chance of this, stated with the estimate: 8%; at least 5.2-fold (0.72 log units) between middle value and limit.
By their numbers in this assay, from the lowest: compounds 1 and 3 (each within the scatter of the next); then compound 2. At a limit, above all of these: compound 4.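

In this assay the result for compound 4 is a limit, not a number: the limit of > 50000 nM in this assay, at which 1 of the 4 values shown sits. A single change of aryl group on this amide-type nitrogen can therefore shift the read-out further than any earlier step, with an at least 10-fold higher number from compound 1 to compound 4 (1.01 log units; beyond the scatter), and acetyl in place of methoxy on an aromatic carbon gives an at least 9.2-fold higher number from compound 3 to compound 4 (0.96 log units; beyond the scatter). The remaining step, an at least 1.7-fold higher number from compound 2 to compound 4 (0.23 log units; that floor lies within the scatter), leaves that pair without a firm order. From the compounds shown here alone, the true value of compound 4 stays open. Also open, going by these compounds, is how a 4-carboxyphenyl or 4-hydroxyphenyl group would read on this nitrogen.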